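A few compounds are considered here, and "the series" means these few. Any claim that something is new, unique, unknown or untested is made for them only; others in the source may bear on it.

Measured so far in a functional assay on MCF7 cells (Homo sapiens) for cytotoxicity, read by MTT assay, with a stated time of 72 h; a higher number here means a weaker inhibitor, a lower number a stronger inhibitor:
Compound 1, structure `Cc1ccc2oc(CSc3nc4nc(C)cc(C)n4n3)cc(=O)c2c1`, gives a limit of > 25000 nM.
Compound 2, structure `Cc1cc(C)n2nc(SCc3cc(=O)c4cc(Cl)ccc4o3)nc2n1`, gives a limit of > 25000 nM.
Compound 3, structure `COC(=O)Nc1ccc2c(CSc3nc(C)cc(C)n3)cc(=O)oc2c1`, gives 9900 nM.

In this assay compound 2 stands at a limit only, with no number behind it. Compound 1 also stands at a limit, so the step from compound 1 to compound 2, a step that the two limits leave unreadable from compound 1 to compound 2, cannot be read from the two values. Compound 3, built on a different core, is the only one of the three with a number, and that number shows weak inhibition. For the measured compounds named here, the one firm fact about compound 2 is the limit, (the limit of > 25000 nM in this assay, at which 2 of the 3 values shown sit).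

The next compound, compound 4, structure `Cc1cc(C)n2nc(SCc3cc(=O)c4ccccc4o3)nc2n1`, is compound 2 with hydrogen in place of chloro on an aromatic carbon. Going by the values given here, no measured step bears directly on this change: the single step on record, from compound 1 to compound 2, is unreadable, and it exchanges methyl for chloro rather than chloro for hydrogen. With compound 2 already outside the measurable range, the step from compound 2 to compound 4 is expected to be a step that the limit leaves unreadable from compound 2 to compound 4, without a readable direction. Compound 4 is therefore estimated at 35000 nM, with a range from 10000 nM to 120000 nM, and most likely again reported only as a limit.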

Compound 4, half-maximal inhibitory concentration: > 25000 nM
Compound 4 ended at the assay's limit (the forecaster's own chance of this, stated with the estimate: 70%); the middle value lies beyond the limit too.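

For the compounds shown here, compound 1, compound 2 and compound 4 all stand at a limit of this assay and not at a number, so no step among them can be read: the limit of > 25000 nM in this assay, at which 3 of the 4 values shown sit.

On these data alone, whether chloro, methyl or hydrogen on this aromatic carbon makes any difference to inhibition stays open, since none of the three compounds gives a measurable value.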